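Swapping chloro for methyl on the benzamide ring

The compounds below may be only part of what the source reports. "The series", "measured", "known", "first", "only" and "open" are said of these compounds alone.

Measured compounds so far:
- compound 1 `NC(=O)c1c(NC(=O)c2ccccc2Cl)sc2c1CCN(C(=S)Nc1ccccc1F)C2`: 12600 nM
- compound 2 `NC(=O)c1c(NC(=O)c2ccccc2Cl)sc2c1CCN(C(=S)Nc1ccccc1C(F)(F)F)C2`: 1870 nM
- compound 3 `COc1ccc(NC(=S)N2CCc3c(sc(NC(=O)c4ccccc4Cl)c3C(N)=O)C2)cc1`: 19600 nM

All three share one core and were tested in a functional assay on MKN-74 cells (Homo sapiens) for antiproliferative activity, with a stated time of 24 h; on this read-out lower numbers stand for stronger inhibition and higher numbers for weaker inhibition. Compound 2 stands lowest of the three numbers: the nearest is compound 1, with a 6.7-fold lower number from compound 1 to compound 2 (0.83 log units; beyond the scatter), and the furthest is compound 3, with a 10-fold higher number from compound 2 to compound 3 (1.02 log units; beyond the scatter). Compound 1 and compound 3 sit close together, with a 1.6-fold higher number from compound 1 to compound 3 (0.19 log units; within the scatter).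

Compound 4 `Cc1ccccc1C(=O)Nc1sc2c(c1C(N)=O)CCN(C(=S)Nc1ccccc1C(F)(F)F)C2` is not yet measured. It differs from compound 2 in one place: methyl in place of chloro on an aromatic carbon. The change sits on an aromatic carbon of a six-membered aromatic ring of carbon only, ortho to a large group, on the benzamide side of the molecule rather than the thiourea side.

Among the measured compounds shown here, none of the measured steps touches this ring; all three vary the aryl group on the thiourea nitrogen, and the two steps beyond the scatter both involve the 2-(trifluoromethyl)phenyl group, which compound 4 keeps. The data therefore give no direct guide for a chloro-to-methyl exchange. The expectation for compound 4 is a step of a 1.3-fold higher number from compound 2 to compound 4 (0.13 log units; within the scatter) in this assay, that is, no change beyond the scatter. Compound 4 is estimated at 2500 nM, within the range 900 nM to 7000 nM.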

Compound 4, half-maximal inhibitory concentration: 17400 nM
Compound 4: the middle estimate sits 7.0-fold (0.84 log units) below what was measured; the whole stated range lies below it.
By their numbers in this assay, from the lowest: compound 2; then compounds 1, 4 and 3 (each within the scatter of the next).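

In this assay, the benzamide ring turns out to be a place where exchanging one heavy atom for another counts: with the 2-(trifluoromethyl)phenyl group kept on the thiourea side, the change from 2-chlorophenyl to 2-methylphenyl gives a 9.3-fold higher number from compound 2 to compound 4 (0.97 log units; beyond the scatter). The earlier compounds shown here varied only the aryl group on the thiourea nitrogen, and this step adds that the low number of compound 2 rests on the chloro as well as on the 2-(trifluoromethyl)phenyl group, which alone does not secure it. Nothing measured here accounts for the size of this step.

On these data alone, it stays open whether other groups in this place, such as fluoro, bromo, methoxy or an amine, would track the chloro or the methyl, and what a benzamide ring with hydrogen there would give. As far as these compounds go, it is equally open whether methyl in place of chloro would give a step of similar size with the 2-fluorophenyl group of compound 1 or the 4-methoxyphenyl group of compound 3 on the thiourea nitrogen.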